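The source may report more compounds than this note shows. Statements on the series, on what has been measured and on what is new or still open speak of the compounds shown alone.

Of the compounds shown here, three on a shared core have been measured in a functional assay on HL-60 cells (Homo sapiens) for antiproliferative activity, read by MTT assay, with a stated time of 24 h; a higher number here means a weaker inhibitor, a lower number a stronger inhibitor. Compound 1 `CNC(=O)c1ccccc1Oc1nc(Nc2ccc(Br)cc2)ncc1Br` gives 39700 nM. Compound 3 `CNC(=O)c1ccccc1Oc1nc(Nc2cccc(C)c2)ncc1Br` gives 16200 nM. Compound 2 `CNC(=O)c1ccccc1Oc1nc(Nc2ccc(C(F)(F)F)cc2)ncc1Br` reaches only a limit of this assay, > 50000 nM. The step from bromo to trifluoromethyl is an at least 1.2-fold higher number from compound 1 to compound 2 (0.10 log units; that floor lies within the scatter), a change resting on (the limit of > 50000 nM in this assay, at which 1 of the 3 values shown sits). The other step is a 2.5-fold lower number from compound 1 to compound 3 (0.39 log units; beyond the scatter). Compound 3 thus holds the lowest of the two numbers in this assay, with compound 1 nearest at a higher number and compound 2 sitting at a limit.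

Compound 4 `CNC(=O)c1ccccc1Oc1nc(Nc2cccc(OC)c2)ncc1Br` differs from compound 3 by methoxy in place of methyl on an aromatic carbon. Going by the values given here, no measured step exchanges these two groups. Among the compounds with values here, the one step that touched the same aryl group, a 2.5-fold lower number from compound 1 to compound 3 (0.39 log units; beyond the scatter), replaced the whole ring substituent and was modest, while an at least 1.2-fold higher number from compound 1 to compound 2 (0.10 log units; that floor lies within the scatter) stayed within the scatter at its floor. On this footing the change to compound 4 is expected to bring no step beyond the scatter, read as a 1.0-fold lower number from compound 3 to compound 4 (0.01 log units; within the scatter). Compound 4 is therefore estimated to give 16000 nM in this assay, within a range from 6000 nM to 45000 nM.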

Compound 4, half-maximal inhibitory concentration: 16200 nM
Compound 4: middle estimate off by 1.0-fold (0.01 log units), on the low side; the measured number falls inside the stated range.
By their numbers in this assay, from the lowest: compounds 3 and 4 (each within the scatter of the next); then compound 1. At a limit, above all of these: compound 2.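

In this assay, the exchange of methyl for methoxy on the aromatic carbon is the first change shown that keeps the same place on the ring, and it gives no change at the digits printed from compound 3 to compound 4 (within the scatter), so the added oxygen leaves the read-out where it stood. The 3-methoxyphenyl group also matches the earlier step away from the 4-bromophenyl group, with a 2.5-fold lower number from compound 1 to compound 4 (0.39 log units; beyond the scatter), so two different groups now stand at the level that only compound 3 held before. Nothing among the measurements shown accounts for this match.

As far as these compounds go, whether this place on the ring accepts other kinds of group, such as an amine, a carboxylic acid or a longer chain, remains open. Also open, from the compounds shown here alone, is whether methyl and methoxy would stay matched in any other read-out.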